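Swapping the Amide Side Chain: Cytotoxicity Expected Unchanged

The source may hold more compounds than are shown below. What is called first, only, known or untested is meant among the compounds shown, and "the series" means these compounds.

Compound 1 `CC(C)CNC(=O)[C@H](C)NC(=O)[C@@]1(Cc2ccccc2)CCN1C(=O)OCc1ccccc1`: > 100000 nM (a limit of the test)
Compound 2 `C[C@H](NC(=O)[C@@]1(Cc2ccccc2)CCN1C(=O)OCc1ccccc1)C(=O)NC1CCCCC1`: 100000 nM

For the measured compounds named here, in an ADME assay on HELF cells (Homo sapiens) for cytotoxicity, with a stated time of 3 days (on this read-out lower numbers stand for higher toxicity in this test and higher numbers for lower toxicity in this test), compound 2 gives 100000 nM, the only number measured here. Compound 1 gives > 100000 nM, which is a limit of the test and not a number. Going by the values given here, the single known step, a number no higher from compound 1 to compound 2 (the limit leaves the size open), has no readable size because of the limit of > 100000 nM in this assay, at which 1 of the 2 values shown sits. Compound 3 `CC(C)C[C@H](NC(=O)[C@@]1(Cc2ccccc2)CCN1C(=O)OCc1ccccc1)C(N)=O` differs from compound 2 by 1-carbamoyl-3-methylbutyl in place of 1-(cyclohexylcarbamoyl)ethyl on an amide-type nitrogen. The measured step offers no sign of a change beyond the usual scatter, so compound 3 is expected to give about 100000 nM, within 50000 nM to 200000 nM, an estimated step of no change at the digits printed from compound 2 to compound 3 (within the scatter).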

Compound 3, minimum cytotoxic concentration: > 100000 nM
Compound 3: no number, only a limit; the forecaster's own chance of this, stated with the estimate: 50%; the middle value sits exactly at the limit.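

In this assay compound 3 gives > 100000 nM, which is a limit and not a number. The step here is a number no lower from compound 2 to compound 3 (the limit leaves the size open). This amide-type nitrogen therefore also carries 1-carbamoyl-3-methylbutyl, which has no ring, in place of 1-(cyclohexylcarbamoyl)ethyl, with no sign of higher toxicity. The sizes of the new steps cannot be read because of the assay limit: the limit of > 100000 nM in this assay, at which 2 of the 3 values shown sit. Still open, going by these compounds, is whether an amine or a carboxylic acid on the side chain at this place would give a clearly lower number in this assay.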